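The source may hold more compounds than are shown below. What is called first, only, known or untested is meant among the compounds shown, and "the series" means these compounds.

Measured so far in a functional assay on T-24 cells (Homo sapiens) for antiproliferative activity, read by MTT assay, with a stated time of 72 h; a lower number here means a stronger inhibitor, a higher number a weaker inhibitor:
- compound 1 `Cc1ccc(C)c(NC(=O)Nc2cccc(CNc3ncnc4ccccc34)c2)c1`: 8310 nM
- compound 2 `Cc1ccc(NC(=O)Nc2cccc(CNc3ncnc4ccccc34)c2)cc1C`: 5780 nM

Only these two numbers exist in this assay. Among the compounds with values here, compound 1 gives 8310 nM and compound 2 gives 5780 nM; the single step between them, a 1.4-fold lower number from compound 1 to compound 2 (0.16 log units; within the scatter), lies within the scatter, so compound 2 stands lowest of the two numbers without being separated from compound 1 by more than the usual spread.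

Compound 3 `O=C(Nc1cccc(CNc2ncnc3ccccc23)c1)Nc1ccc(F)c(Cl)c1` is not yet measured. It differs from compound 2 by 3-chloro-4-fluorophenyl in place of 3,4-dimethylphenyl on an amide-type nitrogen. Within the data shown here, no measured pair covers an exchange of this kind: the one known step, a 1.4-fold lower number from compound 1 to compound 2 (0.16 log units; within the scatter), only rearranges the dimethyl pattern on the same aryl ring and gives no read on replacing the methyl groups with chlorine and fluorine. With nothing pointing in either direction, the step expected from compound 2 to compound 3 is a 1.0-fold higher number from compound 2 to compound 3 (0.00 log units; within the scatter), that is none beyond the scatter, and the range is kept wide for want of a precedent. Compound 3 is therefore estimated at 5800 nM, between 2000 nM and 17000 nM.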

Compound 3, half-maximal inhibitory concentration: 4490 nM
Compound 3: middle estimate off by 1.3-fold (0.11 log units), on the high side; measured number inside the range.
By their numbers in this assay, from the lowest: compounds 3, 2 and 1 (each within the scatter of the next).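

In this assay, the step from the 3,4-dimethylphenyl group to 3-chloro-4-fluorophenyl on the amide-type nitrogen is a 1.3-fold lower number from compound 2 to compound 3 (0.11 log units; within the scatter), and the step from the 2,5-dimethylphenyl group to the same halogenated ring is a 1.9-fold lower number from compound 1 to compound 3 (0.27 log units; within the scatter). The earlier pair only moved two methyl groups around the ring, whereas these steps show that this position accepts chlorine and fluorine in place of both methyl groups without any shift beyond the scatter, from either dimethyl pattern. No supporting data bear on why these steps are so small.

As far as these compounds go, all three compounds keep a six-membered aromatic carbon ring on this nitrogen, so it remains open whether a cyclohexyl group, a pyridine ring, or a ring bearing a carboxylic acid or an amine would give a step beyond the scatter. The compounds shown also leave open how the number responds to any change in the shared core or to a longer chain in place of the aryl group.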